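Another methoxy on the carbonyl aryl ring of compound 2

The source may report more compounds than this note shows. Statements on the series, on what has been measured and on what is new or still open speak of the compounds shown alone.

Compound 1, `COc1cc(-c2cc(/C=C/C(=O)c3ccc(Cl)c(Cl)c3)[nH]n2)cc(OC)c1OC`: 10100 nM in a functional assay on 786-0 cells (Homo sapiens) for inhibition, read by sulforhodamine B assay, with a stated time of 48 h; on this read-out higher numbers stand for weaker inhibition of growth and lower numbers for stronger inhibition of growth
Compound 2, `COc1ccc(C(=O)/C=C/c2cc(-c3cc(OC)c(OC)c(OC)c3)n[nH]2)cc1OC`: 1400 nM in this assay
Compound 3, `COc1ccc(C(=O)/C=C/c2cc(-c3cc(OC)c(OC)c(OC)c3)n[nH]2)cc1`: 1950 nM in this assay

Among the three measured compounds, compound 2 gives the lowest number in this assay. Its nearest neighbour is compound 3, which lies within the scatter of it, so the two cannot be ranked against each other; the furthest is compound 1, separated by a 7.2-fold lower number from compound 1 to compound 2 (0.86 log units; beyond the scatter). The move from compound 1 to compound 3 is of similar size, a 5.2-fold lower number from compound 1 to compound 3 (0.71 log units; beyond the scatter).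

Compound 4, `COc1cc(C(=O)/C=C/c2cc(-c3cc(OC)c(OC)c(OC)c3)n[nH]2)cc(OC)c1OC`, differs from compound 2 in one place: methoxy in place of hydrogen on an aromatic carbon. Among the measured compounds shown here, the one measured step that bears on this is the removal of a methoxy from the same ring, a 1.4-fold higher number from compound 2 to compound 3 (0.14 log units; within the scatter), which stayed within the scatter. Adding a methoxy to that ring is the same kind of change in the other direction, so no step beyond the scatter is expected in this assay for compound 4.

Compound 4 is therefore estimated at 1300 nM in this assay, with a range from 500 nM to 3500 nM. The expected step from its parent is a 1.1-fold lower number from compound 2 to compound 4 (0.03 log units; within the scatter), which is within the scatter.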

Compound 4, concentration for 50% growth inhibition: 1560 nM
Compound 4: middle estimate off by 1.2-fold (0.08 log units), on the low side; the range from low to high includes it.
By their numbers in this assay, from the lowest: compounds 2, 4 and 3 (each within the scatter of the next); then compound 1.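

In this assay, adding a methoxy to the carbonyl aryl ring of compound 2, at the carbon ortho to a methoxy group and meta to a large group, leaves the number within the scatter (a 1.1-fold higher number from compound 2 to compound 4 (0.05 log units; within the scatter)). Among the compounds shown here, the earlier compounds showed only the removal of a methoxy from this ring, which also stayed within the scatter (a 1.4-fold higher number from compound 2 to compound 3 (0.14 log units; within the scatter)), so changes in both directions from compound 2 now give no step beyond the scatter, while the only step on this ring that exceeds it remains the change from the 3,4-dichlorophenyl of compound 1 (a 7.2-fold lower number from compound 1 to compound 2 (0.86 log units; beyond the scatter)). No available evidence accounts for this insensitivity to the number of methoxy groups.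

The compounds shown leave open whether this carbon tolerates only methoxy or also a different substituent, such as a hydroxyl, an amine, a carboxylic acid or a longer ethoxy chain. They also leave open whether a carbonyl aryl ring with no methoxy at all would stay within the scatter of compound 2 or move away from it as compound 1 does.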